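The compounds below may be only part of what the source reports. "The series", "measured", "known", "first", "only" and "open" are said of these compounds alone.

In a functional assay on HeLa cells (Homo sapiens) for antiproliferative activity, read by MTT assay, with a stated time of 48 h (a lower number here means a stronger inhibitor, a higher number a weaker inhibitor), compound 3 `COc1cc(-c2nnc3c(OC4CCC4)cc(-c4ccc5c(ccn5C)c4)cn23)cc(OC)c1OC` gives 177 nM as its result. Compound 2 `COc1cc(-c2nnc3c(OC4COC4)cc(-c4ccc5c(ccn5C)c4)cn23)cc(OC)c1OC` gives 214 nM and compound 1 `COc1cc(-c2nnc3c(OC4CC4)cc(-c4ccc5[nH]ccc5c4)cn23)cc(OC)c1OC` gives 119 nM here, so all three numbers lie within the usual scatter of one another and compound 3 cannot be ranked against them.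

Compound 4 `COc1cc(-c2nnc3c(OC4CC4)cc(-c4ccc5c(ccn5C)c4)cn23)cc(OC)c1OC` has not been measured yet. It carries cyclopropyl in place of cyclobutyl on an oxygen on an aromatic ring and is otherwise the same as compound 3.

For the measured compounds named here, the one measured step at this place is a 1.2-fold lower number from compound 2 to compound 3 (0.08 log units; within the scatter) with oxetan-3-yl giving way to cyclobutyl. Compound 1 also has cyclopropyl on that oxygen and gives 119 nM as its result, but it differs from compound 4 elsewhere, so it is only a loose guide. On this evidence, no step beyond the scatter is expected in this assay and no clear direction can be called. The estimated change is a 1.1-fold lower number from compound 3 to compound 4 (0.06 log units; within the scatter) and this is expected to be small. The estimate for compound 4 is 155 nM with an expected range from 85 nM to 280 nM in this measurement.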

Compound 4, half-maximal inhibitory concentration: 97 nM
Compound 4: the middle estimate sits 1.6-fold (0.20 log units) above what was measured; measured number inside the range.
By their numbers in this assay, from the lowest: compounds 4, 1, 3 and 2 (each within the scatter of the next, the first and the last beyond it).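

For the compounds shown here, the change from cyclobutyl to cyclopropyl on this oxygen gives a 1.8-fold lower number from compound 3 to compound 4 (0.26 log units; within the scatter) in this assay and so does not separate the two rings, while the change from oxetan-3-yl to cyclopropyl gives a 2.2-fold lower number from compound 2 to compound 4 (0.34 log units; beyond the scatter) and is the first step at this oxygen to pass the scatter, though only modestly. Methyl on the aromatic nitrogen of the other ring system gives a 1.2-fold lower number from compound 1 to compound 4 (0.09 log units; within the scatter) and so cannot be told apart from hydrogen there. Nothing available explains why these numbers fall as they do.

The compounds shown carry only small rings on this oxygen, which leaves open how an open chain such as ethyl, or a chain ending in an amine, would read in this assay here. The methyl and hydrogen comparison also rests on this single pair.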